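The source may report more compounds than this note shows. Statements on the series, on what has been measured and on what is new or still open speak of the compounds shown alone.

Measured compounds:
Compound 1, `CCCc1nnc(SCC(=O)c2ccc(Cl)cc2)n1N1C(=O)c2ccccc2C1=O` — in a functional assay on PC-3M cells (Homo sapiens) for cytotoxicity, read by MTT assay, with a stated time of 48 h (on this read-out higher numbers stand for weaker inhibition and lower numbers for stronger inhibition), compound 1 gives > 200000 nM.
Compound 2, `COc1cc(-c2nnc(SCC(=O)c3ccc(Cl)cc3)n2N2C(=O)c3ccccc3C2=O)cc(OC)c1OC` — in this assay compound 2 gives 20700 nM.

The value for compound 1 in this assay is a limit of the assay rather than a number, as the limit of > 200000 nM in this assay, at which 1 of the 2 values shown sits, records. For the measured compounds named here, compound 2 therefore stands as the only compound with a number in this assay; the single measured step, an at least 9.6-fold lower number from compound 1 to compound 2 (0.98 log units; beyond the scatter), runs from that limit to this number, so its true size is not known beyond being at least modest.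

Compound 3, `COc1ccc(C(=O)CSc2nnc(-c3cc(OC)c(OC)c(OC)c3)n2N2C(=O)c3ccccc3C2=O)cc1`, is the next compound to be measured. It differs from compound 2 by methoxy in place of chloro on an aromatic carbon. Going by the values given here, no measured step touches this position: the one measured step, an at least 9.6-fold lower number from compound 1 to compound 2 (0.98 log units; beyond the scatter), concerns the propyl-to-trimethoxyphenyl exchange on the shared core and says nothing about the ring that carries the chloro. With no evidence bearing on the change, the expectation is a step within the usual scatter, in no particular direction, so that compound 3 is estimated at 22000 nM in this assay, within 7000 nM to 80000 nM. The expected step is a 1.1-fold higher number from compound 2 to compound 3 (0.03 log units; within the scatter).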

Compound 3, half-maximal inhibitory concentration: 32800 nM
For compound 3 the middle estimate is 1.5-fold (0.17 log units) below the measured one, and the stated range covers the measured number.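

The ring that carries the chloro in compound 2 now has a measured step of its own. In this assay the exchange of 4-chlorophenyl for 4-methoxyphenyl gives a 1.6-fold higher number from compound 2 to compound 3 (0.20 log units; within the scatter) and so lies within the scatter: on this aromatic carbon, para to a large group, the change does not separate the two compounds, and both give a number with 3,4,5-trimethoxyphenyl on the shared core. Nothing shown gives a reason for this outcome or bears on the exchange beyond the step itself.

The compounds shown leave open whether a group of another kind at this place on the ring, such as an amine or a carboxylic acid, or a longer chain on the oxygen of the methoxy, would also stay within the scatter of compound 2. From the compounds shown here alone, compound 1, with propyl on the shared core, is a limit of the assay and not a number, so it also stays open whether the same exchange of chloro for methoxy would read alike with propyl in place of 3,4,5-trimethoxyphenyl.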